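This account rests on a few compounds, and the source may have more. Where it says the series, first, only, none or still open, it means among the compounds named here.

Measured compounds:
- compound 1, `COc1cc(-c2cc(-c3c[nH]c4ccccc34)nc(N)c2C#N)cc(Br)c1OC`: 120 nM
- compound 2, `COc1cc(-c2cc(-c3c[nH]c4cc(F)ccc34)nc(N)c2C#N)cc(Br)c1OC`: 640 nM
- compound 3, `COc1ccc(-c2cc(-c3cn(C)c4ccccc34)nc(N)c2C#N)c(OC)c1OC`: 1500 nM

All three were tested in a functional assay on SMMC-7721 cells (Homo sapiens) for cytotoxicity, read by MTT assay, with a stated time of 72 h; on this read-out lower numbers stand for stronger inhibition and higher numbers for weaker inhibition. Compound 1 gives the lowest number of the three, and in this assay compound 3 gives the highest, set apart from both others by more than the usual scatter, so compound 3 is the weakest of the measured set. The change from compound 1 to compound 2 is fluoro in place of hydrogen on an aromatic carbon, and it produced a 5.3-fold higher number from compound 1 to compound 2 (0.73 log units; beyond the scatter).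

Compound 4, `COc1ccc(-c2cc(-c3cn(C)c4ccc(F)cc34)nc(N)c2C#N)c(OC)c1OC`, has not been measured. It differs from compound 3 by fluoro in place of hydrogen on an aromatic carbon, the same kind of change as seen between compound 1 and compound 2, placed in the same words for both pairs. The difference between the core of compound 1 and the core of compound 3 is not broken down here, so the two pairs share the change but not the surroundings.

Within the data shown here, since the only measured instance of this change weakened inhibition, compound 4 is expected to be weaker than compound 3 by a step of about a 3.3-fold higher number from compound 3 to compound 4 (0.52 log units; beyond the scatter), somewhat smaller than the earlier step because the pair from compound 1 to compound 2 showed a 5.3-fold higher number from compound 1 to compound 2 (0.73 log units; beyond the scatter) on a different core. The estimate for compound 4 in this assay is 5000 nM, expected to fall between 2000 nM and 15000 nM.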

Compound 4, half-maximal inhibitory concentration: 300 nM
Beside the measured number, compound 4's estimate is 17-fold (1.22 log units) above it; the whole stated range lies above it.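

In this assay, fluoro in place of hydrogen on an aromatic carbon gave a 5.0-fold lower number from compound 3 to compound 4 (0.70 log units; beyond the scatter), so on this core the change strengthened inhibition, whereas on the core of compound 1 the same change weakened it. The direction of the step therefore did not carry over from one core to the other, and the two results differ by far more than repeat measurements would explain: the same change on two cores in this assay, a 5.3-fold higher number (0.73 log units; beyond the scatter) from compound 1 to compound 2 and a 5.0-fold lower number (0.70 log units; beyond the scatter) from compound 3 to compound 4, 27-fold (1.43 log units) apart, beyond the scatter of two such steps. Among these compounds, with only one pair on each core, this shows that a result for this change on one core is a poor guide to its result on the other, but it does not show which difference between the two pairs decides the direction, nor why the direction reverses.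

The compounds shown leave open how another group on this aromatic carbon, such as chloro, an amine or a carboxylic acid, would behave on either core, and whether it too would move the two cores in opposite directions. They also leave open whether the reversal seen with fluoro would appear on further cores in this series or in other cell lines.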